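Bromo for benzyloxy on a pair of bis-chalcone cores

The source may report more compounds than this note shows. Statements on the series, on what has been measured and on what is new or still open speak of the compounds shown alone.

The account covers four compounds sharing a hydroxylated bis-enone core, measured or to be measured in a functional assay on MCF7 cells (Homo sapiens) for cytotoxicity, read by MTT assay, with a stated time of 24 h; on this read-out higher numbers stand for weaker inhibition and lower numbers for stronger inhibition. Compound 1 `Cc1cc(O)c(C(=O)/C=C/c2ccc(F)cc2)c(-c2ccc(OCc3ccccc3)cc2)c1C(=O)/C=C/c1ccc(F)cc1` carries a benzyloxy group on its pendant ring and fluorine on both styryl rings; in this assay compound 1 gives 28000 nM. Compound 3 `Cc1cc(O)c(C(=O)/C=C/c2ccc(F)cc2)c(-c2ccc(Br)cc2)c1C(=O)/C=C/c1ccc(F)cc1` is its bromo counterpart, and in this assay compound 3 gives 20000 nM. The change between them is bromo in place of benzyloxy on an aromatic carbon, and it made a 1.4-fold lower number from compound 1 to compound 3 (0.15 log units; within the scatter), so the two values cannot be told apart.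

Compound 2 `Cc1cc(O)c(C(=O)/C=C/c2ccc(Cl)cc2)c(-c2ccc(OCc3ccccc3)cc2)c1C(=O)/C=C/c1ccc(Cl)cc1` is the chloro analogue of compound 1; how the core of compound 2 differs from the core of compound 1 is not broken down here. In this assay compound 2 is reported as "not active" (no number reported), without a number.

Compound 4 `Cc1cc(O)c(C(=O)/C=C/c2ccc(Cl)cc2)c(-c2ccc(Br)cc2)c1C(=O)/C=C/c1ccc(Cl)cc1` has not been measured. For the measured compounds named here, it differs from compound 2 by bromo in place of benzyloxy on an aromatic carbon, the same kind of change as the one from compound 1 to compound 3, with the place described in the same words. Going by the values given here, since compound 2 has no number, no sized step can be written from compound 2 to compound 4; what can be said is that the same exchange from compound 1 to compound 3 gave a 1.4-fold lower number from compound 1 to compound 3 (0.15 log units; within the scatter), so little shift is expected here either. Compound 4 is therefore expected to stay weak, estimated at 40000 nM, between 15000 nM and 120000 nM, with a real chance that the assay again reports no number.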

Compound 4, half-maximal inhibitory concentration: 20000 nM
Compound 4: middle estimate off by 2.0-fold (0.30 log units), on the high side; low and high end bracket the measured number.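

Compound 2 is reported without a number in this assay, while compound 4 gives 20000 nM, so no sized step can be read between these two compounds. The compounds shown leave open how far, if at all, bromo in place of benzyloxy shifts the read-out when chlorine sits on the styryl rings. No further measurement shown bears on this result.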